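Taking the methoxy off compound 1

A few compounds are considered here, and "the series" means these few. Any claim that something is new, unique, unknown or untested is made for them only; others in the source may bear on it.

Measured in a functional assay on ASPC1 cells (Homo sapiens) for cytotoxicity; on this read-out higher numbers stand for weaker inhibition and lower numbers for stronger inhibition:
compound 1 `COc1ccc2nc(NC(=O)CCCCC(=O)NO)sc2c1`: 23.9 ug/mL
compound 2 `O=C(CCCCCCC(=O)Nc1nc2ccc([N+](=O)[O-])cc2s1)NO`: 1.65 ug/mL
compound 3 `COc1ccc2nc(NC(=O)CCCCCCC(=O)NO)sc2c1`: 0.79 ug/mL

Compound 1 has the highest number of the three, which makes it the weakest inhibitor here, and the values of both other compounds lie beyond the usual scatter beneath it. Compound 4 `O=C(CCCCC(=O)Nc1nc2ccccc2s1)NO` keeps the chain of compound 1 and differs in one place: hydrogen in place of methoxy on an aromatic carbon. In short, it has hydrogen in place of methoxy on an aromatic carbon.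

Two measured steps can be weighed against this change. The large one, a 30-fold lower number from compound 1 to compound 3 (1.48 log units; beyond the scatter), comes from lengthening the chain by a 2-(hydroxycarbamoyl)ethyl swap, and compound 4 has no such change, so it offers no guide. The nearer guide is a swap on an aromatic carbon, nitro to methoxy, and it gave only a modest 2.1-fold lower number from compound 2 to compound 3 (0.32 log units; beyond the scatter). For the measured compounds named here, no compound with hydrogen at that carbon has been measured, so the direction stays open, and that swap was also seen only with the longer chain. No step beyond the scatter is therefore expected in this assay. The estimated step is a 1.1-fold lower number from compound 1 to compound 4 (0.04 log units; within the scatter). For compound 4 the expected value is 22 ug/mL, with an estimated range of 9 ug/mL to 55 ug/mL.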

Compound 4, half-maximal inhibitory concentration: 10.2 ug/mL
Estimate against measurement, compound 4: 2.2-fold (0.33 log units) above; low and high end bracket the measured number.
By their numbers in this assay, from the lowest: compound 3; then compound 2; then compound 4; then compound 1.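

For the compounds shown here, this is the first direct reading of what the methoxy itself contributes at this aromatic carbon: in this assay removing it and leaving hydrogen gives a 2.3-fold lower number from compound 1 to compound 4 (0.37 log units; beyond the scatter) while the shorter chain stays unchanged. The methoxy is therefore not required for the cytotoxicity seen with this chain, something the earlier swap of nitro for methoxy, read only on the longer chain, could not show. The gain is much smaller than a 30-fold lower number from compound 1 to compound 3 (1.48 log units; beyond the scatter) seen on lengthening the chain, and nothing measured here explains the effect of removing the methoxy.

Going by these compounds, what stays open is whether hydrogen would also give a lower number than methoxy on the longer chain of compound 3, where only nitro and methoxy are on view, and so whether the chain change and the removal of the methoxy would add up. On these data alone, it is equally open how other groups on this aromatic carbon, such as fluoro, an amine or a hydroxyl, would compare with hydrogen and methoxy on the shorter chain of compound 4.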